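Alkoxy chain length on the shared core

This account rests on a few compounds, and the source may have more. Where it says the series, first, only, none or still open, it means among the compounds named here.

Among the measured compounds shown here, compound 2 `CCCOc1cc(C(C)(C)C)ccc1C/N=C(\S)NCc1ccc(NS(C)(=O)=O)cc1` gives the lower of the two numbers so far in a functional assay for inhibition of Vanilloid receptor (Rattus norvegicus) (a higher number here means a weaker inhibitor, a lower number a stronger inhibitor), at 250 nM. For the measured compounds named here, compound 1 `CCOc1cc(C(C)(C)C)ccc1C/N=C(\S)NCc1ccc(NS(C)(=O)=O)cc1`, which carries a shorter chain on the aromatic oxygen, gives 1100 nM in this assay, and the step of a 4.4-fold lower number from compound 1 to compound 2 (0.64 log units; beyond the scatter) is the one measured change. Compound 3 `CCCCCOc1cc(C(C)(C)C)ccc1C/N=C(\S)NCc1ccc(NS(C)(=O)=O)cc1` carries the change (ethyl in place of hydrogen on a saturated chain carbon, three bonds along the chain from an oxygen on an aromatic ring), which continues the same chain further out from the oxygen on the aromatic ring. Going by the values given here, the one measured step bears on it directly, since both steps lengthen the same chain; that step was modest and beyond the scatter. A further gain of similar or somewhat smaller size is therefore expected in this assay, though nothing measured shows whether a longer chain keeps helping. The expected step from compound 2 to compound 3 is a 2.1-fold lower number from compound 2 to compound 3 (0.32 log units; beyond the scatter). Compound 3 is expected to give about 120 nM, within a range from 40 nM to 500 nM.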

Compound 3, half-maximal inhibitory concentration: 70 nM
Compound 3: the middle estimate sits 1.7-fold (0.23 log units) above what was measured, and the stated range covers the measured number.
By their numbers in this assay, from the lowest: compound 3; then compound 2; then compound 1.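

In this assay the chain on the aromatic oxygen keeps giving lower numbers beyond propyl: the change from propyl to pentyl gives a 3.6-fold lower number from compound 2 to compound 3 (0.55 log units; beyond the scatter), again a modest step, so the trend runs through all the compounds shown with none against it. Across the whole series the result is a 16-fold lower number from compound 1 to compound 3 (1.20 log units; beyond the scatter), a large change, which makes compound 3 the strongest inhibitor of the three. Nothing measured here accounts for this trend.

As far as these compounds go, whether a longer chain such as heptyl or octyl lowers the number further, or the trend stops or reverses beyond pentyl, remains open. Also open, from the compounds shown here alone, is how a branched chain such as isopropyl, or a chain ending in an amine or a carboxylic acid, would compare with the plain pentyl chain on the shared core.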